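A few compounds are considered here, and "the series" means these few. Any claim that something is new, unique, unknown or untested is made for them only; others in the source may bear on it.

Measured in an ADME assay on HCT-116 cells (Homo sapiens) for cytotoxicity, read by CellTiter-Glo, with a stated time of 72 h; a higher number here means a weaker inhibitor, a lower number a stronger inhibitor:
- Compound 1 `Cc1noc(C)c1S(=O)(=O)N1CCC(N2CCC(C)CC2)CC1`: > 10000 nM
- Compound 2 `CC1CCN(C2CCN(S(=O)(=O)c3cccnc3)CC2)CC1`: > 10000 nM
- Compound 3 `CC1CCN(C2CCN(S(=O)(=O)c3cnc(Cl)s3)CC2)CC1`: > 10000 nM

Compound 3 has only a limit, > 10000 nM, and not a number. The whole series sits in the same place: the limit of > 10000 nM in this assay, at which 3 of the 3 values shown sit.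

The change to compound 4 `CC1CCN(C2CCN(S(=O)(=O)c3ccc(Cl)nc3)CC2)CC1` is 6-chloropyridin-3-yl in place of 2-chloro-1,3-thiazol-5-yl on a sulfonyl sulfur. The measured steps that bear on it also exchange the group on the sulfonyl sulfur, and neither gives a size: a step that the two limits leave unreadable from compound 1 to compound 3 and a step that the two limits leave unreadable from compound 2 to compound 3. With no readable step to draw on, no change beyond the scatter is expected in this assay, and another limit is the likeliest result. The expected step is a step that the limit leaves unreadable from compound 3 to compound 4. For compound 4 the estimated value is 15000 nM, with an expected range from 7000 nM to 30000 nM.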

Compound 4, half-maximal inhibitory concentration: > 10000 nM
Compound 4: a limit, no number; the forecaster's own chance of this, stated with the estimate: 85%; the middle value does not contradict the limit.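

In this assay compound 4 gives > 10000 nM, a limit and not a number, so its steps from compound 1, compound 2 and compound 3 cannot be read. The series stays at one value: the limit of > 10000 nM in this assay, at which 4 of the 4 values shown sit. The compounds shown leave open whether exchanging the group on the sulfonyl sulfur changes the inhibition at all.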